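Swapping phenoxy for isobutylsulfanyl at the tolerance limit

The source may hold more compounds than are shown below. What is called first, only, known or untested is meant among the compounds shown, and "the series" means these compounds.

In an ADME assay on cells (Fibroblast, Gallus gallus) for cytotoxicity, read by CCK-8 assay, with a stated time of 48 h (a higher number here means that more compound is tolerated, a lower number that less compound is tolerated), compound 3 `CCC(CC)O[C@@H]1C=C(C(=O)O)C[C@H](NCc2ccc(Oc3ccccc3)cc2)[C@H]1NC(C)=O` stands at > 200000 nM as a limit and not a number. Compound 1 `CCC(CC)O[C@@H]1C=C(C(=O)O)C[C@H](NCc2ccc(Cc3ccccc3)cc2)[C@H]1NC(C)=O` gives > 200000 nM as a limit too. Compound 2 `CCC(CC)O[C@@H]1C=C(C(=O)O)C[C@H](NCc2ccc(OC)cc2)[C@H]1NC(C)=O` gives > 200000 nM as a limit as well. For the measured compounds named here, the record so far is therefore the limit of > 200000 nM in this assay, at which 3 of the 3 values shown sit, and no compound in the set has yet given a true number.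

Compound 4 `CCC(CC)O[C@@H]1C=C(C(=O)O)C[C@H](NCc2ccc(SCC(C)C)cc2)[C@H]1NC(C)=O` differs from compound 3 in a single group isobutylsulfanyl in place of phenoxy on an aromatic carbon with isobutylsulfanyl in place of phenoxy on an aromatic carbon.

Three measured steps change a group at that same place, namely a step that the two limits leave unreadable from compound 1 to compound 2 and a step that the two limits leave unreadable from compound 1 to compound 3 and a step that the two limits leave unreadable from compound 2 to compound 3 so none offers a size to carry over. Benzyl, methoxy and phenoxy all end at the same limit, so no step beyond the usual scatter is expected in this assay in either direction. The expected size is a number no higher from compound 3 to compound 4 (the limit leaves the size open) in this estimate. For compound 4 the estimate is 200000 nM with an expected range from 100000 nM to 400000 nM and another limit is the likeliest report.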

Compound 4, half-maximal cytotoxic concentration: > 200000 nM
Compound 4 was reported as a limit; the forecaster's own chance of this, stated with the estimate: 85%; the middle value sits exactly at the limit.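

For the compounds shown here, compound 1, compound 2, compound 3 and compound 4 all give limits rather than numbers in this assay, so no step among them can be read: the limit of > 200000 nM in this assay, at which 4 of the 4 values shown sit. Going by these compounds, whether benzyl, methoxy, phenoxy and isobutylsulfanyl differ at all in how well the cells tolerate them stays open.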